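From Bromophenyl to Dichlorophenyl: An Expected Gain

This account rests on a few compounds, and the source may have more. Where it says the series, first, only, none or still open, it means among the compounds named here.

Of the compounds shown here, three have so far been measured in an ADME assay on isolated protein for inhibition of Amine oxidase [flavin-containing] B (Homo sapiens); on this read-out higher numbers stand for weaker inhibition and lower numbers for stronger inhibition. Compound 1 `C#CCNC1CCc2c(SCCc3ccc(Br)cc3)cccc21` gives 1250 nM. Compound 2 `C#CCNC1CCc2c(SCc3cccc(F)c3)cccc21` gives 11600 nM, and compound 3 `C#CCNC1CCc2c(SCc3ccc(Cl)c(Cl)c3)cccc21` gives 74 nM. Compound 1 thus stands second highest of the three numbers; its nearest neighbour is compound 2, whose value lies beyond the usual scatter above it, while compound 3 sits furthest away, well below it.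

Compound 4 `C#CCNC1CCc2c(SCCc3ccc(Cl)c(Cl)c3)cccc21` has not yet been measured. It differs from compound 1 in a single place: 3,4-dichlorophenyl in place of 4-bromophenyl on a saturated chain carbon, two bonds along the chain from a sulfur. Among the compounds with values here, no step between measured compounds that differ in one place has been recorded, so this change has no direct precedent. Still, compound 3, which carries the same 3,4-dichlorophenyl group, gives 74 nM, the lowest number of the set, whereas compound 1 with 4-bromophenyl gives 1250 nM. On that basis compound 4 is expected to show a downward step, estimated as a 6.3-fold lower number from compound 1 to compound 4 (0.80 log units; beyond the scatter) and beyond the scatter. The estimate for compound 4 is 200 nM, within a range from 60 nM to 700 nM.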

Compound 4, half-maximal inhibitory concentration: 2820 nM
Compound 4: middle estimate off by 14-fold (1.15 log units), on the low side; the measured number lies above the stated range.
By their numbers in this assay, from the lowest: compound 3; then compound 1; then compound 4; then compound 2.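

In this assay, placing 3,4-dichlorophenyl in place of 4-bromophenyl on a saturated chain carbon, two bonds along the chain from a sulfur, gives a 2.3-fold higher number from compound 1 to compound 4 (0.35 log units; beyond the scatter) as a modest step, so at this position the change weakens inhibition rather than strengthening it. The 3,4-dichlorophenyl group therefore does not bring a low number wherever it stands: compound 3 gives 74 nM and compound 4, carrying the same group on its longer chain, gives 2820 nM in the same assay. No measurement at hand accounts for this outcome.

The compounds shown leave open whether 4-chlorophenyl or unsubstituted phenyl on the same chain would give a number closer to compound 1 or to compound 4. They also leave open how a longer chain would behave with either group.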